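Butyl in place of fluoro on the aroyl acrylic acid core

A few compounds are considered here, and "the series" means these few. Any claim that something is new, unique, unknown or untested is made for them only; others in the source may bear on it.

The series shares a core in which an aromatic ring carries an unsaturated keto acid chain, as in compound 1 `O=C(O)/C=C/C(=O)c1ccccc1`. In a functional assay on LS174T cells (Homo sapiens) for inhibition, read by MTT assay, with a stated time of 72 h (on this read-out lower numbers stand for stronger inhibition and higher numbers for weaker inhibition), compound 1 gives 45500 nM. Within the data shown here, compound 2 `O=C(O)/C=C/C(=O)c1ccc(F)cc1` carries fluoro on the ring, and in this assay compound 2 gives 33800 nM; the step of a 1.3-fold lower number from compound 1 to compound 2 (0.13 log units; within the scatter) is the only measured step that changes one place on this ring. Compound 3 `Cc1ccc(C(=O)/C=C/C(=O)O)cc1C`, with two methyl groups on the ring, gives 12100 nM in this assay. Among the three measured numbers compound 2 stands second highest, close to compound 1 and well apart from compound 3.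

The unmeasured compound 4 `CCCCc1ccc(C(=O)/C=C/C(=O)O)cc1` differs from compound 2 in one place: butyl in place of fluoro on an aromatic carbon. Among the measured compounds shown here, no measured step exchanges fluoro for an alkyl chain, so the only direct bearing comes from the small step from compound 1 to compound 2 and from the lower number that compound 3, which carries two methyl groups, shows against compound 2. On that basis the step of a 2.8-fold lower number from compound 2 to compound 4 (0.45 log units; beyond the scatter) is expected to be modest and downward, but with wide uncertainty. Compound 4 is therefore estimated at 12000 nM, in a range from 3500 nM to 40000 nM.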

Compound 4, half-maximal inhibitory concentration: 6740 nM
For compound 4 the middle estimate is 1.8-fold (0.25 log units) above the measured one; the range from low to high includes it.
By their numbers in this assay, from the lowest: compounds 4 and 3 (each within the scatter of the next); then compounds 2 and 1 (each within the scatter of the next).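

Butyl on an aromatic carbon, para to a group of 7 heavy atoms, gives the first single change in the compounds shown that moves the number beyond the scatter in this assay: the replacement of fluoro gives a 5.0-fold lower number from compound 2 to compound 4 (0.70 log units; beyond the scatter) and the replacement of hydrogen gives a 6.8-fold lower number from compound 1 to compound 4 (0.83 log units; beyond the scatter) on the same read-out. Fluoro at this place gave only a 1.3-fold lower number from compound 1 to compound 2 (0.13 log units; within the scatter) and stayed within the scatter, so this place does not respond alike to every group put there, and a chain of 4 carbon atoms changes the number where a single fluorine did not. Neither fluoro nor butyl brings hydrogen-bond donors, hydrogen-bond acceptors or a net charge, and nothing measured alongside these numbers accounts for the step, which therefore stands as an observation only.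

The compounds shown leave open whether a shorter chain such as ethyl or a longer chain such as hexyl would carry the trend further at this place. They also leave open how an amine or a methoxy group would behave there, and whether butyl keeps its step when the carboxylic acid of the shared core is replaced by an ester.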